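The source may hold more compounds than are shown below. What is called first, only, known or untested is meant among the compounds shown, and "the series" means these compounds.

Of the compounds shown here, two sharing one core have been measured so far. Compound 1 `Cc1nc(S(C)(=O)=O)ccc1Oc1ncnc(OC2CCN(C(=O)OC3CCC3)CC2)c1F` carries a cyclobutyl on an oxygen next to a carbonyl group, and in a functional assay on isolated protein for inhibition of Glucose-dependent insulinotropic receptor (Homo sapiens), read by HTRF and cAMP accumulation (on this read-out lower numbers stand for an effect already at smaller amounts and higher numbers for an effect only at larger amounts of compound), compound 1 gives 13.6 nM. Compound 2 `Cc1nc(S(C)(=O)=O)ccc1Oc1ncnc(OC2CCN(C(=O)OC3(C(F)(F)F)COC3)CC2)c1F` has a 3-(trifluoromethyl)oxetan-3-yl in place of that cyclobutyl, and in this assay compound 2 gives 29.3 nM. That single measured step, a 2.2-fold higher number from compound 1 to compound 2 (0.33 log units; beyond the scatter), leaves compound 2 with the higher of the two numbers, compound 1 being the nearest neighbour at the lower one.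

Compound 3 `Cc1nc(S(C)(=O)=O)ccc1Oc1ncnc(OC2CCN(C(=O)SC3CC3)CC2)c1F` is not yet measured. Relative to compound 2 the change is a group of 4 heavy atoms (3 carbon, 1 sulfur; one three-membered non-aromatic ring of carbon only) in place of a group of 9 heavy atoms (4 carbon, 2 oxygen, 3 fluorine; one four-membered non-aromatic ring with 1 hetero atom), on a carbonyl carbon. Going by the values given here, only the step from compound 1 to compound 2 bears on this, and it shows that a swap at this carbonyl moves the number modestly. The expected step is a 1.6-fold lower number from compound 2 to compound 3 (0.21 log units; within the scatter), a modest move toward a lower number, because a small carbon-only ring at this position is what compound 1 shows with 13.6 nM. Compound 3 is therefore estimated at 18 nM, with a range from 7 nM to 45 nM.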

Compound 3, half-maximal effective concentration: 24.9 nM
Compound 3: the middle estimate sits 1.4-fold (0.14 log units) below what was measured; the range from low to high includes it.
By their numbers in this assay, from the lowest: compounds 1, 3 and 2 (each within the scatter of the next, the first and the last beyond it).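

In this assay, the step of a 1.2-fold lower number from compound 2 to compound 3 (0.07 log units; within the scatter) lies within the scatter, so a much smaller group on the carbonyl carbon, 4 heavy atoms against 9, leaves the number indistinguishable from that of the group with the 3-(trifluoromethyl)oxetan-3-yl ring. The step of a 1.8-fold higher number from compound 1 to compound 3 (0.26 log units; within the scatter) also lies within the scatter, which places compound 3 within reach of both earlier compounds even though those two stand beyond the scatter of each other, and it shows that this position accepts a sulfur-linked group with a three-membered carbon ring without a clear move in the number. Nothing shown here explains why these numbers fall as they do.

The swap changes the linking atom and the ring together, so the share of the sulfur and the share of the ring size cannot be separated, and a sulfur carrying the cyclobutyl ring would be needed to pull them apart. An amine linked to the carbonyl carbon through its nitrogen, or an open butyl chain in place of the ring, also remains an open question at this position.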